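Alkyl branching on the amide nitrogen chain, working notes

The source may hold more compounds than are shown below. What is called first, only, known or untested is meant among the compounds shown, and "the series" means these compounds.

Measured so far:
compound 1 `Cc1ccc(-n2nccn2)c(C(=O)N(C)CCn2ccc(-c3ccc(F)cn3)n2)c1` — 5.54 nM
compound 2 `Cc1ccc(-n2nccn2)c(C(=O)N(C)[C@@H](C)Cn2ccc(-c3ccc(F)cn3)n2)c1` — 1.9 nM
compound 3 `Cc1ccc(-n2nccn2)c(C(=O)N(C)[C@@H](C)Cn2cc(-c3ccc(F)cn3)cn2)c1` — 4.39 nM

All three were run in a functional assay on cells for antagonist activity at Orexin/Hypocretin receptor type 1 (Homo sapiens), read by fluorescence and calcium flux, with a stated time of 30 min; a lower number here means a stronger inhibitor, a higher number a weaker inhibitor. Compound 1 gives 5.54 nM and compound 2 gives 1.9 nM; the change between them is methyl in place of hydrogen on a saturated chain carbon bound to an amide-type nitrogen and a saturated chain carbon, and the step is a 2.9-fold lower number from compound 1 to compound 2 (0.46 log units; beyond the scatter). Compound 3 gives 4.39 nM; the difference between the cores of compound 1 and compound 3 is not broken down here.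

Compound 4 `CCN(C(=O)c1cc(C)ccc1-n1nccn1)[C@@H](C)Cn1cc(-c2ccc(F)cn2)cn1` is not yet measured. It differs from compound 3 by methyl in place of hydrogen on a saturated chain carbon bound to an amide-type nitrogen. This is the same kind of change as that from compound 1 to compound 2, but the place differs: there the carbon was bound to an amide-type nitrogen and a saturated chain carbon, here to an amide-type nitrogen only, so the earlier step is only a loose guide. The step from compound 3 to compound 4 in this assay is expected to be a 1.1-fold lower number from compound 3 to compound 4 (0.04 log units; within the scatter), resting on compound 2 at 1.9 nM and the wide range left open by the differing place. Compound 4 is estimated at 4 nM, between 1.5 nM and 12 nM.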

Compound 4, half-maximal inhibitory concentration: 0.767 nM
Compound 4: middle estimate off by 5.2-fold (0.72 log units), on the high side; the measured number lies below the stated range.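

In this assay, methyl in place of hydrogen on a saturated chain carbon bound to an amide-type nitrogen gives a 5.7-fold lower number from compound 3 to compound 4 (0.76 log units; beyond the scatter). The number falls on both cores, and the two steps do not differ in size beyond the scatter: the same change on two cores in this assay, a 2.9-fold lower number (0.46 log units; beyond the scatter) from compound 1 to compound 2 and a 5.7-fold lower number (0.76 log units; beyond the scatter) from compound 3 to compound 4, 2.0-fold (0.29 log units) apart, within the scatter of two such steps Within these two pairs the change therefore carries from one core to the other, but two pairs do not show that it would hold on a further core, and they do not explain the drop in either case.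

Still open, as far as these compounds go, is whether a longer chain, such as propyl in place of the ethyl of compound 4, would lower the number further or raise it again.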